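Swapping fluoro for dimethylamino on an inactive core

The source may hold more compounds than are shown below. What is called first, only, known or untested is meant among the compounds shown, and "the series" means these compounds.

Compound 1 `CCOC(=O)C12C(=O)OCC=C1COC2c1ccc(F)cc1` is one of three close analogues tested in a functional assay on QGY cells (Homo sapiens) for cytotoxicity, read by MTT assay; on this read-out higher numbers stand for weaker inhibition and lower numbers for stronger inhibition. In this assay compound 1 gives only a limit, > 1000000 nM. Compound 2 `CCOC(=O)C12C(=O)OCC=C1COC2c1ccc(OC)c(OC)c1` likewise gives a limit, > 1000000 nM. Compound 3 `CCOC(=O)C12C(=O)OCC=C1COC2c1cc(OC)cc(OC)c1` gives a limit too, > 1000000 nM. All three sit at the limit of > 1000000 nM in this assay, at which 3 of the 3 values shown sit, so compound 1 stands level with the other two and none can be separated. Compound 4 `CCOC(=O)C12C(=O)OCC=C1COC2c1ccc(N(C)C)cc1` has not yet been measured; it differs from compound 1 by dimethylamino in place of fluoro on an aromatic carbon. For the measured compounds named here, no measured step exists for this change, and no shift beyond the scatter is expected. Compound 4 is therefore expected to give about 1000000 nM, within 300000 nM to 3000000 nM. The expected step of a number no higher from compound 1 to compound 4 (the limit leaves the size open) is none beyond the scatter.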

Compound 4, half-maximal inhibitory concentration: > 1000000 nM
Compound 4 was reported as a limit (the forecaster's own chance of this, stated with the estimate: 85%); the middle value lies on the limit itself.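

No step can be read from compound 1 to compound 4, because both compounds give only a limit: the limit of > 1000000 nM in this assay, at which 4 of the 4 values shown sit.

The compounds shown leave open whether any substituent on the aromatic ring of the shared core would give a measurable value in this assay.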